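The compounds below may be only part of what the source reports. "The series", "measured", "known", "first", "only" and "open" are said of these compounds alone.

Measured in a functional assay on L1210 cells (Mus musculus) for inhibition; on this read-out higher numbers stand for weaker inhibition and lower numbers for stronger inhibition:
- Compound 1 `CC(=O)CC1C[C@@H](CCCCCCCC#C[C@@H](O)COCCOC[C@@H](O)c2ccccc2)OC1=O`: 19800 nM
- Compound 2 `COc1ccc([C@H](O)COCCOC[C@H](O)C#CCCCCCCC[C@@H]2CC(CC(C)=O)C(=O)O2)cc1`: > 10000 nM

The entry for compound 2 is a limit of this assay and not a number. It therefore gives no exact position for compound 2, and only compound 1 has a true measured value.

The next compound is compound 3 `CC(=O)CC1C[C@@H](CCCCCCCC#C[C@@H](O)COCCOC[C@@H](O)c2ccc(C(F)(F)F)cc2)OC1=O`. It keeps the rest of compound 2 and changes one group on the aromatic ring, with trifluoromethyl in place of methoxy on an aromatic carbon.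

For the measured compounds named here, only one measured step bears on this change: a step that the limit leaves unreadable from compound 1 to compound 2. It also concerns a group on an aromatic carbon, but it has no readable size, and the data are thin: the limit of > 10000 nM in this assay, at which 1 of the 2 values shown sits. It therefore offers no direction for the new change.

The best anchor is compound 1 at 19800 nM, so weak inhibition is expected to continue, with no step beyond the scatter. The expected change is a step that the limit leaves unreadable from compound 2 to compound 3, and this could still end in a limit rather than a number. The estimated value for compound 3 is 15000 nM, with an expected range of 5000 nM to 40000 nM.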

Compound 3, half-maximal inhibitory concentration: 3300 nM
Compound 3: middle estimate off by 4.5-fold (0.66 log units), on the high side; measured number outside the range, below it.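

In this assay, this position on the aromatic ring, para to a large group, now proves able to change the read-out. Trifluoromethyl there gives the first step with a readable size, a 6.0-fold lower number from compound 1 to compound 3 (0.78 log units; beyond the scatter), so the substituent is not merely carried along without effect. Set against methoxy at the same position, the change gives an at least 3.0-fold lower number from compound 2 to compound 3 (0.48 log units; beyond the scatter), which shows that the two substituents also differ from each other and not only from the unsubstituted ring. That second step gives only a smallest possible size and not an exact one, because the entry for compound 2 is a limit and not a number: the limit of > 10000 nM in this assay, at which 1 of the 3 values shown sits.

Going by these compounds, whether a chlorine atom, a nitrile or a carboxylic acid at this same position would also lower the number remains open, so one favourable group cannot yet be read as a trend. On these data alone, it is also open whether trifluoromethyl would give a similar step at another carbon of the ring or on a shorter chain, since all three compounds share one core and one substitution site.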